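The source may report more compounds than this note shows. Statements on the series, on what has been measured and on what is new or still open speak of the compounds shown alone.

Of the compounds shown here, two of one series have been measured in an in vitro ADME assay on microsomes from liver (Homo sapiens) for metabolic stability; a lower number here means that the compound disappears faster, a higher number that the compound lasts longer. Compound 1, `NC(=O)COc1ccc2c(c1)S(=O)(=O)N=C(c1c(O)c(-c3cccs3)nn(CC3CCC3)c1=O)N2`, gives 0.367 h in this assay. Compound 2, `CC(C)CCn1nc(-c2nccs2)c(O)c(C2=NS(=O)(=O)c3cc(OCC(N)=O)ccc3N2)c1=O`, reaches only the limit of the measurement in this assay, reported as > 1 h. Its standing in this assay is therefore known only as a limit: the limit of > 1 h in this assay, at which 1 of the 2 values shown sits. Compound 3, `NC(=O)COc1ccc2c(c1)S(=O)(=O)N=C(c1c(O)c(-c3nccs3)nn(CC3CCC3)c1=O)N2`, has not yet been measured in this assay. It differs from compound 2 in one place, (cyclobutyl in place of isobutyl on a saturated chain carbon bound to an aromatic nitrogen); one bond further out this reads as isopentyl to cyclobutylmethyl. Going by the values given here, no measured pair shows this change, so its effect rests on expectation alone. The step of an at least 1.2-fold lower number from compound 2 to compound 3 (0.09 log units; that floor lies within the scatter) is expected to be a modest decrease, near the edge of the scatter. Compound 3 is thus estimated at 0.8 h in this assay. For compound 3 the expected range runs from 0.35 h to 1.8 h.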

Compound 3, half-life: > 1 h
Compound 3: no number, only a limit; the forecaster's own chance of this, stated with the estimate: 35%; middle value at least 1.2-fold (0.09 log units) from the limit.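

In this assay, going by these compounds alone, 1,3-thiazol-2-yl in place of thiophen-2-yl on an aromatic carbon, with cyclobutylmethyl held the same, gives an at least 2.7-fold higher number from compound 1 to compound 3 (0.43 log units; beyond the scatter), the first readable step and one that lies beyond the scatter. For compound 3 the result > 1 h is a limit of the assay and not a number. The step from isopentyl to cyclobutylmethyl cannot be read, as compound 2 and compound 3 stand at the same limit: the limit of > 1 h in this assay, at which 2 of the 3 values shown sit.

From the compounds shown here alone, how far compound 2 and compound 3 lie past that limit stays open, and with it any difference between isopentyl and cyclobutylmethyl. Also open, going by these compounds, is how a phenyl in place of 1,3-thiazol-2-yl, or a longer chain in place of cyclobutylmethyl, would fare in this assay.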